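A few compounds are considered here, and "the series" means these few. Any claim that something is new, unique, unknown or untested is made for them only; others in the source may bear on it.

Compound 1 `CCOc1cc2[nH]c(Cc3nn(CC(=O)N4CCOCC4)c(=O)c4ccccc34)nc2cc1Cl` is the point of reference in a functional assay on CHO cells for antagonist activity at sphingosine 1-phosphate receptor 2 (Homo sapiens), read by calcium flux (a lower number here means a stronger inhibitor, a higher number a weaker inhibitor), where compound 1 gives 10 nM. Among the numbers that are not limits, compound 1 stands lowest, and the nearest neighbour is compound 3 `O=C(Cc1nn(CC(=O)N2CCOCC2)c(=O)c2ccccc12)Nc1ccc(OC(F)(F)F)c(Cl)c1`, which in this assay gives 30 nM, a gap that lies beyond the scatter. Compound 2 `COc1ccc(Cl)cc1NC(=O)Cc1nn(CC(=O)O)c(=O)c2ccccc12` carries a carboxymethyl group on the shared core in place of the ((morpholin-4-yl)carbonyl)methyl group of compound 3, together with a different amide substituent. In this assay compound 2 reaches only a limit, > 1790 nM, with no number beneath it (the limit of > 1790 nM in this assay, at which 1 of the 3 values shown sits).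

Compound 4 `CCOc1cc2[nH]c(Cc3nn(CC(=O)O)c(=O)c4ccccc34)nc2cc1Cl` is the untested relative of compound 1. Among the measured compounds shown here, the change is hydroxy in place of morpholin-4-yl on a carbonyl carbon; no measured pair repeats exactly this step on the same core. The two values shown for compound 2 and compound 3 suggest that the carboxy series sits at the weak end, so a move toward weaker inhibition, well beyond the scatter, is expected in this assay. The step from compound 1 to compound 4 is estimated at a 60-fold higher number from compound 1 to compound 4 (1.78 log units; beyond the scatter). Compound 4 is therefore expected to give about 600 nM, within 100 nM to 3000 nM.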

Compound 4, half-maximal inhibitory concentration: 17 nM
Compound 4: middle estimate off by 35-fold (1.55 log units), on the high side, and the stated range ends above it.
By their numbers in this assay, from the lowest: compounds 1, 4 and 3 (each within the scatter of the next, the first and the last beyond it). At a limit, above all of these: compound 2.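

In this assay, hydroxy in place of morpholin-4-yl on a carbonyl carbon gives a 1.7-fold higher number from compound 1 to compound 4 (0.23 log units; within the scatter). On the core of compound 1, then, the morpholine ring is not needed to keep inhibition at this level, and a carboxymethyl group is tolerated there as well as a ((morpholin-4-yl)carbonyl)methyl group. The carboxymethyl group alone therefore does not put a compound at the weak end, although compound 2, which also carries it, gives only a limit and not a number: the limit of > 1790 nM in this assay, at which 1 of the 4 values shown sits.

Whether the same exchange holds with the amide substituent of compound 3 stays open, since that pair cannot be read from the compounds shown. Also open, as far as these compounds go, is how other groups on this carbonyl carbon would behave, such as a simple primary amide, a methyl ester or a piperazine.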